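The source may hold more compounds than are shown below. What is called first, only, known or untested is meant among the compounds shown, and "the series" means these compounds.

Compound 1 `C=C[C@@](C)(/C=C/c1ccc(OCc2cn(Cc3ccc(F)cc3)nn2)cc1)CCC=C(C)C` and compound 2 `C=C[C@@](C)(/C=C/c1ccc(OCc2cn(Cc3ccc(C)cc3)nn2)cc1)CCC=C(C)C` share one core, while compound 3 `C=C[C@@](C)(/C=C/c1ccc(OC(=O)c2cn(-c3ccc(F)cc3)nn2)cc1)CCC=C(C)C` and compound 4 `C=C[C@@](C)(/C=C/c1ccc(OC(=O)c2cn(-c3ccc(C)cc3)nn2)cc1)CCC=C(C)C` share another; the difference between the two cores is not broken down here. In a toxicity assay on RAW264.7 cells (Mus musculus) for cytotoxicity, read by MTT assay, with a stated time of 24 h (a lower number here means a stronger inhibitor, a higher number a weaker inhibitor), compound 1 gives 157000 nM, and compound 2 gives 371000 nM. The change between them, (methyl in place of fluoro on an aromatic carbon), produced a 2.4-fold higher number from compound 1 to compound 2 (0.37 log units; beyond the scatter). In this assay compound 3 gives 79900 nM; compound 1 lies within the scatter of it, compound 2 beyond it. Compound 4 carries the same change on the second core, (methyl in place of fluoro on an aromatic carbon), and the place described for it matches that of the first pair word for word. For compound 4 a step of similar size is expected, a 2.1-fold higher number from compound 3 to compound 4 (0.33 log units; beyond the scatter), because the earlier change gave a 2.4-fold higher number from compound 1 to compound 2 (0.37 log units; beyond the scatter). Compound 4 is therefore estimated to give 170000 nM in this assay, between 80000 nM and 360000 nM.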

Compound 4, half-maximal inhibitory concentration: 37200 nM
The estimate for compound 4 lay 4.6-fold (0.66 log units) above the measured number; measured number outside the range, below it.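

In this assay, methyl in place of fluoro gave a 2.1-fold lower number from compound 3 to compound 4 (0.33 log units; beyond the scatter), so the step seen on the first core did not carry over to the second, where it ran the opposite way. The two steps differ in direction, and the gap between them lies beyond the scatter: the same change on two cores in this assay, a 2.4-fold higher number (0.37 log units; beyond the scatter) from compound 1 to compound 2 and a 2.1-fold lower number (0.33 log units; beyond the scatter) from compound 3 to compound 4, 5.1-fold (0.71 log units) apart, beyond the scatter of two such steps. For these two pairs, the outcome of the change therefore went with the core, but this does not show which difference between the cores is responsible, and two pairs set no rule for the series.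

The compounds shown leave open how chloro, methoxy or an amine at this place would behave on either core. Also open, from the compounds shown here alone, is how the change would run on two cores that differ in only one place.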